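Dropping the propargyl from compound 2: what to expect

The compounds below may be only part of what the source reports. "The series", "measured", "known", "first", "only" and "open" are said of these compounds alone.

Measured so far:
compound 1 `CCNCc1cn(Cc2ccccc2)c2ccccc12` with 263000 nM
compound 2 `C#CCN(Cc1ccccc1)Cc1cc2ccccc2n1C` with 10000 nM
compound 3 `CC#CCN(C)Cc1cc2cc(O)ccc2n1C` with 5.75 nM

In an assay on isolated protein for inhibition of Amine oxidase [flavin-containing] A (Rattus norvegicus) (a higher number here means a weaker inhibitor, a lower number a stronger inhibitor), compound 2 gives 10000 nM, the second highest of the three numbers. Its nearest neighbour is compound 1, whose value in this assay is clearly higher, while compound 3 sits far lower. Compound 4 `Cn1c(CNCc2ccccc2)cc2ccccc21` has not been measured; compared with compound 2 the change is hydrogen in place of propargyl on an amine nitrogen. Compound 1, also a secondary amine carrying a benzyl group, gives the weakest value of the set, and the only strong inhibitor, compound 3, keeps an alkyne on the amine nitrogen. Compound 4 is therefore expected to be weaker than compound 2, with a step of a 10-fold higher number from compound 2 to compound 4 (1.00 log units; beyond the scatter) beyond the scatter. The estimate for compound 4 is 100000 nM, between 30000 nM and 300000 nM.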

Compound 4, inhibition constant: 33900 nM
The estimate for compound 4 lay 2.9-fold (0.47 log units) above the measured number, and the stated range covers the measured number.
By their numbers in this assay, from the lowest: compound 3; then compound 2; then compound 4; then compound 1.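

In this assay, replacing the propargyl on the amine nitrogen with hydrogen has only a modest effect (a 3.4-fold higher number from compound 2 to compound 4 (0.53 log units; beyond the scatter)). Among the compounds shown here, this is the first reading of a single change at this nitrogen, and it shows that, with the benzyl group in place, the propargyl accounts for only a small part of the range spanned by these compounds. No available evidence explains the size of this step. The compounds shown leave open whether a methyl group at this nitrogen would behave like hydrogen or like propargyl, and thus whether the triple bond itself matters.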